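A few compounds are considered here, and "the series" means these few. Any claim that something is new, unique, unknown or untested is made for them only; others in the source may bear on it.

Of the compounds shown here, two have been tested in a functional assay on the whole organism for displacement of a labelled ligand, with Rattus norvegicus as the target, at a dose of 3.2 mg/kg by the subcutaneous route (on this read-out lower numbers stand for less inhibition and higher numbers for more inhibition at the one dose given (going by the name of the read-out)), so far. Compound 1, `C/C=C(\CC)Oc1cc(C)nc(Oc2c(C)cc(C)cc2C)c1C`, gives 75%, the higher of the two numbers seen. Compound 2, `CCc1c(OC(CC)CC)cc(C)nc1Oc1c(C)cc(C)cc1C`, gives 57%, which lies below compound 1 by more than the usual scatter. These two compounds differ in more than one place, so no single structural step can be read from them.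

Compound 3, `CCC(COC)Oc1cc(C)nc(Oc2c(C)cc(C)cc2C)c1C`, has not yet been measured. It differs from compound 1 in one place: 1-(methoxymethyl)propyl in place of 1-ethylprop-1-en-1-yl on an oxygen on an aromatic ring. The group that leaves carries one double bond outside aromatic rings; the group that enters carries one hydrogen-bond acceptor instead.

For the measured compounds named here, with no step of this kind among the measured pairs, the expectation rests on the standing of compound 1 alone. Compound 3 is expected to lie somewhat below it, by a step of a number 15 percentage points lower from compound 1 to compound 3 (beyond the scatter), close to the edge of the scatter. The estimated value for compound 3 is 60%, within a range from 35% to 85%.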

Compound 3, a percentage reported as inhibition, in the whole organism at one dose (the size of the read-out at that dose, not a potency): 75%
Compound 3: the middle estimate sits 15 percentage points below what was measured; the measured number falls inside the stated range.
By their numbers in this assay, from the lowest: compound 2; then compounds 1 and 3 (each within the scatter of the next).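

In this assay, putting 1-(methoxymethyl)propyl in place of 1-ethylprop-1-en-1-yl on the oxygen gives no change at the digits printed from compound 1 to compound 3 (within the scatter). At this one place on the shared core, then, the double bond of the leaving group can be lost and a hydrogen-bond acceptor brought in without the number moving beyond the usual scatter. No measurement is at hand to say why the two groups read alike.

On these data alone, whether the same place would accept other groups, such as a chain ending in an amine, a carboxylic acid or a longer plain carbon chain, stays open. A figure from one dose also cannot tell whether compound 1 and compound 3 would still read alike at other doses.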